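The compounds below may be only part of what the source reports. "The series", "measured", "known", "first", "only" and "open" are said of these compounds alone.

Measured in a functional assay on HepG2 cells (Homo sapiens) for antiproliferative activity, read by MTT assay, with a stated time of 72 h; a higher number here means a weaker inhibitor, a lower number a stronger inhibitor:
- compound 1 `COc1cccc(N2C(=O)COc3ccc(-c4cccc(NS(=O)(=O)c5ccc(F)cc5)c4)cc32)c1`: > 40000 nM
- compound 2 `O=C1COc2ccc(-c3ccc(O)cc3)cc2N1`: 38200 nM
- compound 3 `COc1ccc(N2C(=O)COc3ccc(-c4cnc(OC)c(NS(=O)(=O)c5ccc(F)cc5)c4)cc32)cc1`: 13100 nM

Compound 1 gives > 40000 nM, which is a limit of the assay and not a number. As far as these compounds go, this places it at the limit of > 40000 nM in this assay, at which 1 of the 3 values shown sits, so its true potency remains unknown.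

The next compound to be tested is compound 4 `O=C1COc2ccc(-c3cccc(NS(=O)(=O)c4ccc(F)cc4)c3)cc2N1C1CCCCC1`. It keeps the core of compound 1 but has cyclohexyl in place of 3-methoxyphenyl on an amide-type nitrogen in a ring.

Within the data shown here, no measured pair of compounds shows what this exchange does, so there is no earlier step to borrow a size from. Among the measured compounds shown here, the only guide is the general level of the numbers: compound 2 gives 38200 nM and compound 3 gives 13100 nM, both high values on a scale where lower means stronger. In this assay, the expected step of an at least 1.3-fold lower number from compound 1 to compound 4 (0.12 log units; that floor lies within the scatter) is therefore none beyond the scatter, with no firm direction.

Compound 4 is estimated at 30000 nM, with an expected range of 12000 nM to 60000 nM.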

Compound 4, half-maximal inhibitory concentration: 35900 nM
Beside the measured number, compound 4's estimate is 1.2-fold (0.08 log units) below it, and the stated range covers the measured number.
By their numbers in this assay, from the lowest: compound 3; then compounds 4 and 2 (each within the scatter of the next). At a limit, above all of these: compound 1.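

In this assay, cyclohexyl on the amide-type nitrogen in a ring gives a readable number: compound 4 stands at 35900 nM, still a high value on a scale where lower means stronger. The exchange of 3-methoxyphenyl for cyclohexyl gives an at least 1.1-fold lower number from compound 1 to compound 4 (0.04 log units; that floor lies within the scatter), so this position can carry a non-aromatic ring of carbon only and still give a number, but the data show no gain beyond the scatter. Compound 1 stands at a limit of the assay, and the true size of the step stays open because its value is not a number: the limit of > 40000 nM in this assay, at which 1 of the 4 values shown sits.

As far as these compounds go, it remains open whether an ethyl chain, a morpholine ring or a carboxylic acid on this nitrogen would lower the number. From the compounds shown here alone, it is also open whether cyclohexyl would act the same way on the core of compound 3.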